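Ring-closed enone on the pyrazole core

The source may report more compounds than this note shows. Statements on the series, on what has been measured and on what is new or still open speak of the compounds shown alone.

Compound 1 `COc1cc(-c2cc(/C=C/C(C)=O)[nH]n2)cc(OC)c1OC` carries the shared core with a 2-acetylethenyl group on an aromatic carbon. In a functional assay on MDA-MB-231 cells (Homo sapiens) for inhibition, read by MTT assay, with a stated time of 48 h (on this read-out lower numbers stand for stronger inhibition and higher numbers for weaker inhibition), compound 1 gives 27300 nM, the highest of the two numbers measured. Among the compounds with values here, its only neighbour is compound 2 `COc1cc(-c2cc(/C=C/C(=O)c3ccccc3)[nH]n2)cc(OC)c1OC`, which in this assay gives 2300 nM; the step of a 12-fold lower number from compound 1 to compound 2 (1.07 log units; beyond the scatter) comes from phenyl in place of methyl on a carbonyl carbon. Compound 3 `COc1cc(-c2cc(/C=C3\CCCCC3=O)[nH]n2)cc(OC)c1OC` is not yet measured. It differs from compound 1 by a group of 8 heavy atoms (7 carbon, 1 oxygen; one six-membered non-aromatic ring of carbon only) in place of a group of 5 heavy atoms (4 carbon, 1 oxygen; no ring), on an aromatic carbon. The change again enlarges the carbonyl-bearing group, this time by closing it into a six-membered ring rather than by adding phenyl, so the step from compound 1 to compound 2 bears on it only loosely. A lower number is expected, but a smaller one than that seen for phenyl. For compound 3 the estimate is 8000 nM with a range from 2500 nM to 25000 nM, corresponding to an expected step of a 3.4-fold lower number from compound 1 to compound 3 (0.53 log units; beyond the scatter).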

Compound 3, half-maximal inhibitory concentration: 17800 nM
Compound 3: middle estimate off by 2.2-fold (0.35 log units), on the low side; the measured number falls inside the stated range.
By their numbers in this assay, from the lowest: compound 2; then compounds 3 and 1 (each within the scatter of the next).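

In this assay, closing the carbonyl-bearing group into a six-membered non-aromatic ring of carbon only gives a 1.5-fold lower number from compound 1 to compound 3 (0.19 log units; within the scatter), so a larger group at this place does not in itself reproduce the step seen with phenyl, a 12-fold lower number from compound 1 to compound 2 (1.07 log units; beyond the scatter). Of the two larger groups, only phenyl on the carbonyl carbon gives a step beyond the scatter, which shows that the count of heavy atoms alone does not set the number in this small set. Nothing available accounts for this result.

The compounds shown leave open whether ethyl or a longer chain on the carbonyl carbon would behave like methyl or like phenyl, and whether a five-membered carbon ring would match the six-membered one. They also leave open how compound 2, at 2300 nM, would change if its phenyl carried an amine or a carboxylic acid.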